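Benzyl for phenyl on the ring nitrogen of compound 1

The source may report more compounds than this note shows. Statements on the series, on what has been measured and on what is new or still open speak of the compounds shown alone.

Measured so far:
compound 1, `Cc1cc2c(c(=O)[nH]1)C(=O)O/C2=C\c1ccc(CO)n1-c1ccccc1`: 61400 nM
compound 2, `CCOC(=O)c1ccc(-n2c(/C=C3\OC(=O)c4c3cc(C)[nH]c4=O)ccc2CO)cc1`: 41200 nM

Compound 1 carries the highest number of the two measured in an assay on isolated protein for inhibition of alpha-mannosidase (Canavalia ensiformis), read by spectrophotometry, with a stated time of 10 min; on this read-out lower numbers stand for stronger inhibition and higher numbers for weaker inhibition. Its neighbour is compound 2, which in this assay gives 41200 nM; the step of a 1.5-fold lower number from compound 1 to compound 2 (0.17 log units; within the scatter) lies within the scatter. Compound 3, `Cc1cc2c(c(=O)[nH]1)C(=O)O/C2=C\c1ccc(CO)n1Cc1ccccc1`, is not yet measured. It differs from compound 1 by benzyl in place of phenyl on an aromatic nitrogen, the group sitting on an aromatic nitrogen of a five-membered aromatic ring with 1 nitrogen. Among the measured compounds shown here, no measured step bears on this change: the only step at hand, a 1.5-fold lower number from compound 1 to compound 2 (0.17 log units; within the scatter), concerns an ethoxycarbonyl on an aromatic carbon and says nothing about the nitrogen substituent. The expectation for compound 3 therefore rests on compound 1 alone, and no step beyond the scatter is expected in this assay. Compound 3 is estimated at 60000 nM, within 20000 nM to 180000 nM, which means an expected step of a 1.0-fold lower number from compound 1 to compound 3 (0.01 log units; within the scatter).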

Compound 3, half-maximal inhibitory concentration: 92300 nM
For compound 3 the middle estimate is 1.5-fold (0.19 log units) below the measured one, within the range that was stated.
By their numbers in this assay, from the lowest: compounds 2, 1 and 3 (each within the scatter of the next, the first and the last beyond it).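

In this assay, among the compounds shown here, putting benzyl in place of phenyl on the aromatic nitrogen gives a 1.5-fold higher number from compound 1 to compound 3 (0.18 log units; within the scatter) and so provides the first reading at this position, where the earlier compounds varied only an aromatic carbon. Across this one change, the six-membered aromatic ring stays in the molecule but is attached through one further carbon, and the two compounds cannot be told apart in this assay. Nothing available explains this result.

The compounds shown leave open whether a longer chain between the nitrogen and the aromatic ring, or a small alkyl group such as methyl in place of that ring, would move the number beyond the scatter. They also leave open what an amine or a carboxylic acid on the benzyl ring would do.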